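Bromo to chloro on the aryl ketone across two cores

The source may report more compounds than this note shows. Statements on the series, on what has been measured and on what is new or still open speak of the compounds shown alone.

Compound 1 `Cc1ccc(S/C(=C/c2c[nH]c3ccc(Br)cc23)C(=O)c2ccc(Br)cc2)cc1` and compound 2 `Cc1ccc(S/C(=C/c2c[nH]c3ccc(Br)cc23)C(=O)c2ccc(Cl)cc2)cc1` share one core, while compound 3 `O=C(/C(=C\c1ccc(Br)cc1)SCc1ccc(F)cc1)c1ccc(Br)cc1` and compound 4 `O=C(/C(=C\c1ccc(Br)cc1)SCc1ccc(F)cc1)c1ccc(Cl)cc1` share another; the difference between the two cores is not broken down here. In a functional assay on DU-145 cells (Homo sapiens) for inhibition, read by trypan blue exclusion, with a stated time of 96 h (a lower number here means a stronger inhibitor of growth, a higher number a weaker inhibitor of growth), compound 1 gives 1000 nM, and compound 2 gives 1000 nM. The step of no change at the digits printed from compound 1 to compound 2 (within the scatter) belongs to the change (chloro in place of bromo on an aromatic carbon). In this assay compound 3 gives 25000 nM, the highest of the three numbers, and its gap to compound 1 as well as to compound 2 lies beyond the scatter. The change from compound 3 to compound 4 is chloro in place of bromo on an aromatic carbon, the same change as from compound 1 to compound 2, at a place described in the same words. It has been seen only once among the measured compounds, and only on the other core. Because the step of no change at the digits printed from compound 1 to compound 2 (within the scatter) showed no change within the scatter, the step of no change at the digits printed from compound 3 to compound 4 (within the scatter) is expected to remain inside the scatter as well. Compound 4 is therefore estimated at 25000 nM, with a range from 12000 nM to 55000 nM.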

Compound 4, concentration for 50% growth inhibition: 9000 nM
Compound 4: the middle estimate sits 2.8-fold (0.44 log units) above what was measured; measured number outside the range, below it.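

Chloro in place of bromo on an aromatic carbon does not carry over unchanged between the two cores in this assay, and the two steps differ: the same change on two cores in this assay, no change at the digits printed (within the scatter) from compound 1 to compound 2 and a 2.8-fold lower number (0.44 log units; beyond the scatter) from compound 3 to compound 4, 2.8-fold (0.44 log units) apart, beyond the scatter of two such steps

On the core of compound 3, the step reads a 2.8-fold lower number from compound 3 to compound 4 (0.44 log units; beyond the scatter), so a flat result on the core of compound 1 does not fix the result of the same change on the core of compound 3. This rests on a single pair per core, and it does not show which of the differences between the two cores accounts for the gap, nor how the change would behave on a third core.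

The compounds shown leave open how an amine, a methoxy group or a carboxylic acid in place of the halogen on the aryl ketone would read on each core. Also open, from the compounds shown here alone, is whether the step from bromo to chloro would stay the same with a group other than fluoro on the sulfur-linked ring of compound 3.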